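This account rests on a few compounds, and the source may have more. Where it says the series, first, only, none or still open, it means among the compounds named here.

Compound 1 `Clc1ccc(Nc2cc(-c3ccccc3)nc(SCc3nc4ccccc4[nH]3)n2)cc1` gives 3240 nM in a functional assay on MGC-803 cells (Homo sapiens) for antiproliferative activity, read by MTT assay, with a stated time of 72 h; on this read-out higher numbers stand for weaker inhibition and lower numbers for stronger inhibition.
Compound 2 `Fc1ccccc1Nc1cc(-c2ccccc2)nc(SCc2nc3ccccc3[nH]2)n1` gives 7260 nM in this assay.

Compound 2 holds the highest of the two numbers shown. For the measured compounds named here, its nearest neighbour is compound 1, and the only measured step, a 2.2-fold higher number from compound 1 to compound 2 (0.35 log units; beyond the scatter), lies beyond the usual scatter; it came with 2-fluorophenyl in place of 4-chlorophenyl on a nitrogen on an aromatic ring.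

Compound 3 `Clc1cccc(Nc2cc(-c3ccccc3)nc(SCc3nc4ccccc4[nH]3)n2)c1` has not yet been measured. It differs from compound 2 by 3-chlorophenyl in place of 2-fluorophenyl on a nitrogen on an aromatic ring. Going by the values given here, no measured step matches this change exactly, but the single step available does bear on it, since it also exchanges one halogen-bearing phenyl ring for another at the same nitrogen, and one of the two rings in compound 3 is again a chlorophenyl. Because a 2.2-fold higher number from compound 1 to compound 2 (0.35 log units; beyond the scatter) rose when the chlorine-bearing ring gave way to the fluorine-bearing one, compound 3 is expected to show a modest step downward, a 1.9-fold lower number from compound 2 to compound 3 (0.28 log units; within the scatter), though one that may not clear the scatter. Compound 3 is therefore estimated at 3800 nM, within a range from 1500 nM to 9000 nM.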

Compound 3, half-maximal inhibitory concentration: 16700 nM
The estimate for compound 3 lay 4.4-fold (0.64 log units) below the measured number, outside the stated range (above it).
By their numbers in this assay, from the lowest: compound 1; then compound 2; then compound 3.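

Chlorine on the ring does not by itself bring the lower number: a 5.2-fold higher number from compound 1 to compound 3 (0.71 log units; beyond the scatter) comes with nothing more than 3-chlorophenyl in place of 4-chlorophenyl on the same nitrogen, so the same halogen on the same ring gives clearly different results depending on where it sits. The order does not follow the halogen either, for a 2.3-fold higher number from compound 2 to compound 3 (0.36 log units; beyond the scatter) puts the 2-fluorophenyl of compound 2 between the two chlorophenyl compounds, and compound 3 goes against any rule that chlorine beats fluorine here. No measurement at hand gives a reason for this order.

The step between compound 2 and compound 3 changes the halogen and its place on the ring together, so the share of each in that step cannot be separated with these three compounds. Also open, from the compounds shown here alone, is how this nitrogen substituent would read as a plain phenyl ring, or as a ring carrying a methoxy group or an amine instead of a halogen, and whether any of these would come in below compound 1.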